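The source may hold more compounds than are shown below. What is called first, only, known or untested is meant among the compounds shown, and "the series" means these compounds.

For the measured compounds named here, compound 2 `CC1(C)C=C(n2ccccc2=O)c2cc(O)ccc2O1` gives 5.44 in a functional assay (aorta) with Rattus norvegicus as the target (a lower number here means a less potent compound, a higher number a more potent compound, by a factor of ten per unit of this negative logarithm), the lower of the two numbers measured so far; compound 1 `CC1(C)C=C(n2ccccc2=O)c2cc(C(=N)NO)ccc2O1` gives 5.99, and the step of a number 0.55 log units lower from compound 1 to compound 2 (beyond the scatter) is the only measured step available. Compound 3 `CC1(C)C=C(n2ccccc2=O)c2cc(OCC(=O)c3ccccc3)ccc2O1` differs from compound 2 by benzoylmethyl in place of hydrogen on an oxygen on an aromatic ring. Going by the values given here, the measured step exchanges one group for another on the ring itself, so it does not bear directly on adding benzoylmethyl to the oxygen; no measured step does. The expected step of a number 0.06 log units higher from compound 2 to compound 3 (within the scatter) is therefore estimated as none beyond the scatter, and compound 3 is expected at 5.5, within 4.8 to 6.3.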

Compound 3, logarithm of the reciprocal of the active concentration, log(1/C): 5.05
Estimate against measurement, compound 3: 0.45 log units above, and the stated range covers the measured number.
By their numbers in this assay, from the lowest: compound 3; then compound 2; then compound 1.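

In this assay, putting benzoylmethyl in place of hydrogen on the oxygen on the aromatic ring gives a number 0.39 log units lower from compound 2 to compound 3 (beyond the scatter), so this larger group brings no gain here. Compound 3 still gives a measurable response, which shows that this hydrogen is not essential for activity in the assay. Nothing available explains the drop.

On these data alone, whether the loss follows from the whole group or from one part of it remains open. A small methyl, a longer carbon chain or a benzyl group on the same oxygen could help separate these possibilities.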